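Aryl Swap at the Ether Oxygen Against Two Assay Limits

This account rests on a few compounds, and the source may have more. Where it says the series, first, only, none or still open, it means among the compounds named here.

Compound 1 `Cc1nn(C)c(Oc2ccc(I)cc2)c1/C=N\CCCCCOc1cc2oc(=O)cc(C)c2cc1Cl`; in a functional assay on SMMC-7721 cells (Homo sapiens) for antiproliferative activity, read by MTT assay, with a stated time of 72 h (on this read-out lower numbers stand for stronger inhibition and higher numbers for weaker inhibition), compound 1 gives > 25000 nM, which is a limit of the assay and not a number.
Compound 2 `Cc1ccc(Oc2c(/C=N\CCCCCOc3cc4oc(=O)cc(C)c4cc3Cl)c(C)nn2C)cc1`; in this assay compound 2 gives 11100 nM.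
Compound 3 `Cc1nn(C)c(Oc2ccc(F)c(F)c2)c1/C=N\CCCCCCOc1cc2oc(=O)cc(C)c2cc1Cl`; in this assay compound 3 gives > 25000 nM, also a limit and not a number.

Compound 3 thus stands at the limit of > 25000 nM in this assay, at which 2 of the 3 values shown sit, and only compound 2 has a definite number. Compound 4 `Cc1nn(C)c(Oc2ccc(OC(F)(F)F)cc2)c1/C=N\CCCCCCOc1cc2oc(=O)cc(C)c2cc1Cl` differs from compound 3 by 4-(trifluoromethoxy)phenyl in place of 3,4-difluorophenyl on an oxygen on an aromatic ring. Among the measured compounds shown here, the single measured step, an at least 2.2-fold lower number from compound 1 to compound 2 (0.35 log units; beyond the scatter), concerns a different ring and a different group, so it bears only loosely on this change. With compound 3 at a limit, compound 4 is expected to stay near it, the step of an at least 1.2-fold lower number from compound 3 to compound 4 (0.09 log units; that floor lies within the scatter) being estimated as small. Compound 4 is therefore estimated at 20000 nM, within 6000 nM to 60000 nM.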

Compound 4, half-maximal inhibitory concentration: 6350 nM
The estimate for compound 4 lay 3.1-fold (0.50 log units) above the measured number; low and high end bracket the measured number.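

Placing 4-(trifluoromethoxy)phenyl in place of 3,4-difluorophenyl on this oxygen gives a definite number in this assay, with an at least 3.9-fold lower number from compound 3 to compound 4 (0.59 log units; beyond the scatter). This shows that a change at this position alone can bring a compound off the limit by more than the scatter. Compound 3 remains a limit of the assay and not a number, so only a floor is known for the size of this step: the limit of > 25000 nM in this assay, at which 2 of the 4 values shown sit.

The compounds shown leave open how large the step really is. They also leave open whether an amine or a carboxylic acid in place of the trifluoromethoxy group would lower the number further.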